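Chloro for hydrogen on the phenyl ring of compound 1

The compounds below may be only part of what the source reports. "The series", "measured", "known", "first", "only" and "open" are said of these compounds alone.

Compound 1 `c1ccc(Nc2ccc(N3CC4CC(C3)N4)cn2)cc1` carries the shared core with an unsubstituted phenyl ring. For the measured compounds named here, in an assay on cell membranes for displacement of a labelled ligand from Neuronal acetylcholine receptor; alpha4/beta2 (Rattus norvegicus) (a lower number here means a stronger inhibitor, a higher number a weaker inhibitor), compound 1 gives 2.66 nM, the highest of the three numbers measured so far. Compound 2 `O=[N+]([O-])c1ccc(Nc2ccc(N3CC4CC(C3)N4)cn2)cc1` gives 1.76 nM, and compound 3 `FC(F)(F)c1ccc(Nc2ccc(N3CC4CC(C3)N4)cn2)cc1` gives 0.569 nM. The step of a 1.5-fold lower number from compound 1 to compound 2 (0.18 log units; within the scatter) stays within the scatter, whereas a 4.7-fold lower number from compound 1 to compound 3 (0.67 log units; beyond the scatter) is a modest but real lowering, and a 3.1-fold lower number from compound 2 to compound 3 (0.49 log units; beyond the scatter) points the same way. Compound 4 `Clc1cccc(Nc2ccc(N3CC4CC(C3)N4)cn2)c1` differs from compound 1 by chloro in place of hydrogen on an aromatic carbon. Both measured steps put a new group on the same phenyl ring, and only the trifluoromethyl lowered the number beyond the scatter; the nitro did not. With a single chlorine entering, the step is expected to fall between those two outcomes, so compound 4 is expected to show a 1.9-fold lower number from compound 1 to compound 4 (0.28 log units; within the scatter). For compound 4 the estimate in this assay is 1.4 nM, with a range from 0.5 nM to 4 nM.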

Compound 4, inhibition constant: 2.2 nM
For compound 4 the middle estimate is 1.6-fold (0.20 log units) below the measured one; low and high end bracket the measured number.
By their numbers in this assay, from the lowest: compound 3; then compounds 2, 4 and 1 (each within the scatter of the next).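

In this assay, chloro on an aromatic carbon meta to a large group gives a 1.2-fold lower number from compound 1 to compound 4 (0.08 log units; within the scatter), so the change from phenyl to 3-chlorophenyl cannot be told apart from repeat measurement. For the compounds shown here, this adds a second substituted phenyl ring, after the nitro of compound 2, whose step from compound 1 stays within the scatter, while the trifluoromethyl of compound 3 remains the only group here with a step beyond it. Nothing available here explains why the chloro leaves the number unmoved.

The compounds shown leave open whether trifluoromethyl at this same place would lower the number as it does in compound 3, and whether an amine or a carboxylic acid here would move it beyond the scatter. They also leave open how a chlorine would fare at the ring carbon that carries the trifluoromethyl in compound 3.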